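Urea to carbamate exchange on a piperidine carbonyl

The source may hold more compounds than are shown below. What is called first, only, known or untested is meant among the compounds shown, and "the series" means these compounds.

Measured compounds:
- compound 1, `O=C(NCC1CCC1)N1CCC(c2nc(-c3ccc4ccccc4n3)no2)CC1`; in a functional assay on Shh Light II cells (Mus musculus) for inhibition, read by a luciferase reporter (on this read-out lower numbers stand for stronger inhibition and higher numbers for weaker inhibition), compound 1 gives 410 nM
- compound 2, `Cn1c(-c2noc(C3CCN(C(=O)NC4CCS(=O)(=O)CC4)CC3)n2)nc2ccccc21`; in this assay compound 2 gives 350 nM

Compound 1 stands with the highest of the two numbers; its nearest neighbour is compound 2, whose value lies within the scatter of it, so the two cannot be ranked against each other. For the measured compounds named here, no step between measured compounds that differ in a single place is available, so the series gives no measured precedent for the change considered here.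

Compound 3, `O=C(OCc1ccccc1)N1CCC(c2nc(-c3ccc4ccccc4n3)no2)CC1`, is not yet measured. It differs from compound 1 by benzyloxy in place of (cyclobutylmethyl)amino on a carbonyl carbon. Going by the values given here, nothing among the measured compounds shows what this exchange does, so no direction beyond the scatter is expected; the step of a 1.1-fold higher number from compound 1 to compound 3 (0.04 log units; within the scatter) is estimated to stay small. Compound 3 is therefore expected to give about 450 nM, within a range from 120 nM to 1800 nM.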

Compound 3, half-maximal inhibitory concentration: > 2500 nM
Compound 3: only a limit was reported; the forecaster's own chance of this, stated with the estimate: 5%; middle value at least 5.5-fold (0.74 log units) from the limit.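

In this assay compound 3 gives > 2500 nM, which is a limit of the assay and not a number. For the compounds shown here, this is the first measured step at this carbonyl carbon: benzyloxy in place of (cyclobutylmethyl)amino gives an at least 6.0-fold higher number from compound 1 to compound 3 (0.78 log units; beyond the scatter), so on the core of compound 1 the exchange is not neutral in this read-out. The size of the step is only a bound, and the true value of compound 3 stays unknown: the limit of > 2500 nM in this assay, at which 1 of the 3 values shown sits.

The exchange alters both the atom attached to the carbonyl carbon and the group carried on it, and the compounds shown do not separate these two changes. Benzylamino or cyclobutylmethoxy on the same carbonyl carbon would show whether the loss follows the carbamate oxygen or the benzyl group.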